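The source may report more compounds than this note shows. Statements on the series, on what has been measured and on what is new or still open speak of the compounds shown alone.

Measured so far:
Compound 1 `CC(=O)OC1=CC(=O)c2ccccc2C1=O` gives 38800 nM in a functional assay on KB cells (Homo sapiens) for cytotoxicity; a higher number here means a weaker inhibitor, a lower number a stronger inhibitor.
Compound 2 `O=C1C=C(Oc2cccs2)C(=O)c2ccccc21` gives 41500 nM in this assay.
Compound 3 `CC(=O)Oc1ccc2c(c1)C(=O)C=CC2=O` gives 22100 nM in this assay.

The measured pair compound 1 and compound 2 differs by one change, (thiophen-2-yl in place of acetyl on an oxygen on an unsaturated carbon), and that change made a step of a 1.1-fold higher number from compound 1 to compound 2 (0.03 log units; within the scatter). Compound 3 and compound 1 are built from the same atoms joined differently; the difference between their two cores is not broken down here. Compound 3 carries an acetyl on an oxygen on an aromatic ring, and compound 4 `O=C1C=CC(=O)c2cc(Oc3cccs3)ccc21` is the member not yet measured that results when the same kind of change is made on it: thiophen-2-yl in place of acetyl on an oxygen on an aromatic ring. The place is not the same word for word as in the earlier pair, where the oxygen sat on an unsaturated carbon whose other neighbours are a double-bonded ring carbon, rather than on an aromatic ring whose other neighbours are aromatic carbon. Because the earlier change produced a 1.1-fold higher number from compound 1 to compound 2 (0.03 log units; within the scatter), an equally small step is expected here, a 1.1-fold higher number from compound 3 to compound 4 (0.04 log units; within the scatter), and compound 4 is estimated at 24000 nM in this assay, between 10000 nM and 55000 nM.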

Compound 4, half-maximal inhibitory concentration: 18300 nM
Beside the measured number, compound 4's estimate is 1.3-fold (0.12 log units) above it; measured number inside the range.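

In this assay, thiophen-2-yl in place of acetyl on an oxygen on an aromatic ring gave a 1.2-fold lower number from compound 3 to compound 4 (0.08 log units; within the scatter). Set beside the earlier pair, the change behaved alike on the two cores: the same change on two cores in this assay, a 1.1-fold higher number (0.03 log units; within the scatter) from compound 1 to compound 2 and a 1.2-fold lower number (0.08 log units; within the scatter) from compound 3 to compound 4, 1.3-fold (0.11 log units) apart, within the scatter of two such steps. This shows that the exchange left the number within the scatter on both cores, so the small step carried over in this one case, but it does not show that a change with a larger effect would carry across in the same way, and two pairs say nothing about any further core.

The compounds shown carry only acetyl or thiophen-2-yl on that oxygen, so it remains open whether a phenyl ring or a longer alkyl chain there would move the number beyond the scatter, and whether such a step would hold on both cores. All the values also come from this assay, which leaves open how these compounds behave in any other test.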